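The compounds below may be only part of what the source reports. "The series", "measured", "known", "first", "only" and "open" are said of these compounds alone.

In a functional assay on Rec1 cells (Homo sapiens) for inhibition, read by luminescence and CellTiter-Glo, with a stated time of 72 h (on this read-out lower numbers stand for stronger inhibition and higher numbers for weaker inhibition), compound 1 `O=C(CCl)N1CCCC(n2nc(-c3ccc(Oc4ccccc4)cc3)cc2CO)C1` gives 400 nM while compound 2 `O=C(O)c1cc(-c2ccc(Oc3ccccc3)cc2)nn1C1CCCN(C(=O)CCl)C1` gives 2200 nM on the same scale. Compound 3 `C/C=C/C(=O)N1CCCC(n2nc(-c3ccc(Oc4ccccc4)cc3)cc2C(=O)OCC)C1` reads 5100 nM as its number. Compound 2 therefore sits in the middle of the three, with the second highest number.

Compound 4 `C=CC(=O)N1CCCC(n2nc(-c3ccc(Oc4ccccc4)cc3)cc2C(=O)O)C1` has not yet been measured, and it departs from compound 2 in one place. The change vinyl in place of chloromethyl on a carbonyl carbon puts vinyl in place of chloromethyl on a carbonyl carbon.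

For the measured compounds named here, no measured step touches this place directly. Going by the values given here, the only clean step a 5.5-fold higher number from compound 1 to compound 2 (0.74 log units; beyond the scatter) is carboxy in place of hydroxymethyl on an aromatic carbon, so it shows how far one change has moved a number here but not which way the new change will go. Compound 3 also lacks chloromethyl on that carbonyl carbon, and its 5100 nM is a higher number than that of compound 2, but it differs in other places too and offers only a loose hint.

A small rise in the number is therefore expected in this assay and it may well stay within the usual scatter. The estimate is a 1.4-fold higher number from compound 2 to compound 4 (0.13 log units; within the scatter) with wide uncertainty. For compound 4 the estimated value is 3000 nM with an expected range from 800 nM to 10000 nM in this measurement.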

Compound 4, half-maximal inhibitory concentration: 50000 nM
The estimate for compound 4 lay 17-fold (1.22 log units) below the measured number, and the stated range ends below it.
By their numbers in this assay, from the lowest: compound 1; then compound 2; then compound 3; then compound 4.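

For the compounds shown here, putting vinyl in place of chloromethyl on the carbonyl carbon gives a 23-fold higher number from compound 2 to compound 4 (1.36 log units; beyond the scatter) in this assay, which shows that the number is highly sensitive to the group at this place, a place that no earlier pair of compounds had tested. This is also the larger of the two single-place steps now available, the other being a 5.5-fold higher number from compound 1 to compound 2 (0.74 log units; beyond the scatter) for carboxy in place of hydroxymethyl, and it arises even though the two groups have the same heavy-atom count and neither has a hydrogen-bond donor or acceptor, so those counts do not account for the difference. No measurement available here explains why this swap has so large an effect.

As far as these compounds go, whether the same swap would shift the number as far with hydroxymethyl in place of carboxy on the aromatic carbon remains open, as the step has been read only with carboxy present. Also open, from the compounds shown here alone, is how other groups on this carbonyl carbon, such as bromomethyl or a longer chain ending in an amine, would compare with chloromethyl and vinyl.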